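A Biaryl Swap Expected to Lower Lipophilicity

A few compounds are considered here, and "the series" means these few. Any claim that something is new, unique, unknown or untested is made for them only; others in the source may bear on it.

Measured so far in a physicochemical assay for lipophilicity, read by HPLC, at pH 7.5; a higher number here means a more lipophilic compound, a lower number a more polar compound:
compound 1 `CC[C@@H](Nc1c(C#N)c(-c2ccc(-c3cccc(C)c3F)cc2)nc2cnccc12)C(N)=O` gives 3;
compound 2 `CC[C@@H](Nc1c(C#N)c(-c2ccc(Br)cc2)nc2cnccc12)C(=O)O` gives 1.6;
compound 3 `CN(CC(N)=O)c1c(C#N)c(-c2ccc(Br)cc2)nc2cnccc12` gives 2.1.

Compound 1 stands highest of the three, with compound 3 nearest and compound 2 furthest below it. Among the compounds with values here, the one measured step, a number 0.50 log units higher from compound 2 to compound 3 (beyond the scatter), changes the side chain on the shared core and so says nothing direct about the distal aryl ring. Compound 4 `CC[C@@H](Nc1c(C#N)c(-c2ccc(-c3ccccc3NC)cc2)nc2cnccc12)C(N)=O` differs from compound 1 only there: 2-(methylamino)phenyl in place of 2-fluoro-3-methylphenyl on an aromatic carbon. The entering group brings one hydrogen-bond donor and one acceptor where the leaving group had none, so a fall in this assay is expected rather than a rise. Compound 4 is estimated at 2.3, between 1.7 and 2.9. The expected step is a number 0.70 log units lower from compound 1 to compound 4 (beyond the scatter), beyond the scatter.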

Compound 4, distribution coefficient: 2.5
Estimate against measurement, compound 4: 0.20 log units below; low and high end bracket the measured number.
By their numbers in this assay, from the lowest: compound 2; then compound 3; then compound 4; then compound 1.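

Within the data shown here, the earlier step changed only the side chain, so this is the first reading of a change on this aromatic carbon, para to a large group: in this assay, 2-(methylamino)phenyl in place of 2-fluoro-3-methylphenyl gives a number 0.50 log units lower from compound 1 to compound 4 (beyond the scatter), a modest step. Both groups hold 8 heavy atoms, so the number moves with an exchange of atoms and not with a change in heavy-atom count. Nothing measured here explains the step.

Which part of the swap carries it stays open: the entering methylamino group, or the departing fluorine and methyl. An unsubstituted phenyl ring, or a primary amine on the ring in place of methylamino, would bear on that question.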